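This account rests on a few compounds, and the source may have more. Where it says the series, first, only, none or still open, it means among the compounds named here.

Measured so far:
- compound 1 `CCCCCc1cc2c(=O)n(CCC)cnc2s1`: 27.4 ug/mL
- compound 2 `CCCCCCCc1cc2c(=O)n(CC#N)cnc2s1`: > 100 ug/mL (a limit)

Going by the values given here, in an ADME assay on A549 cells (Homo sapiens) for cytotoxicity, read by MTT assay, with a stated time of 11 days (a lower number here means a stronger inhibitor of growth, a higher number a weaker inhibitor of growth), compound 1 gives 27.4 ug/mL, the only plain number in the set. Compound 2 sits at the limit of > 100 ug/mL in this assay, at which 1 of the 2 values shown sits, a limit and not a number. Compound 3 `CCCCCc1cc2c(=O)n(CC3CC3)cnc2s1` differs from compound 1 by cyclopropyl in place of ethyl on a saturated chain carbon bound to an aromatic nitrogen. Among the compounds with values here, no measured pair separates this change, so nothing in the set sizes it; the expectation is a step within the scatter, if anything slightly toward stronger growth inhibition. Compound 3 is therefore estimated at 22 ug/mL, within 8 ug/mL to 60 ug/mL, an expected step of a 1.2-fold lower number from compound 1 to compound 3 (0.10 log units; within the scatter).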

Compound 3, concentration for 50% growth inhibition: > 100 ug/mL
Compound 3 was reported as a limit (the forecaster's own chance of this, stated with the estimate: 10%); middle value at least 4.5-fold (0.65 log units) away from the limit.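

At this position, on a saturated chain carbon bound to an aromatic nitrogen, this assay gives an at least 3.6-fold higher number from compound 1 to compound 3 (0.56 log units; beyond the scatter) for cyclopropyl in place of ethyl, so the change is not silent on the core of compound 1. The reading for compound 3 is a limit and not a number. Compound 1 remains the only compound in the set with a plain number: the limit of > 100 ug/mL in this assay, at which 2 of the 3 values shown sit.

From the compounds shown here alone, whether a longer chain or an amine at this position retains growth inhibition remains open. Compound 2 differs from compound 1 in more than one place, so it gives no reading of this position alone.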